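The source may report more compounds than this note shows. Statements on the series, on what has been measured and on what is new or still open speak of the compounds shown alone.

Compound 1 `CN(C)C/C=C/C(=O)Nc1cc2c(N3CCc4ccccc43)ncnc2cc1O[C@@H]1CCOC1`: 1230 nM in a functional assay on PC-3 cells (Homo sapiens) for antiproliferative activity, read by MTT assay, with a stated time of 72 h; a higher number here means a weaker inhibitor, a lower number a stronger inhibitor
Compound 2 `CCN(CC)C/C=C/C(=O)Nc1cc2c(N3CCc4ccccc43)ncnc2cc1O[C@@H]1CCOC1`: 5780 nM in this assay
Compound 3 `CN(C)C/C=C/C(=O)Nc1cc2c(N3CCCc4ccccc43)ncnc2cc1O[C@@H]1CCOC1`: 4170 nM in this assay

Compound 2 differs from compound 1 by one change, (diethylamino in place of dimethylamino on a saturated chain carbon bound to a double-bonded chain carbon), and this gave a 4.7-fold higher number from compound 1 to compound 2 (0.67 log units; beyond the scatter). Compound 3 differs from compound 1 in its core, (1,2,3,4-tetrahydroquinolin-1-yl in place of 2,3-dihydro-1H-indol-1-yl on an aromatic carbon), and this gave a 3.4-fold higher number from compound 1 to compound 3 (0.53 log units; beyond the scatter). Compound 4 `CCN(CC)C/C=C/C(=O)Nc1cc2c(N3CCCc4ccccc43)ncnc2cc1O[C@@H]1CCOC1` has not been measured; it differs from compound 3 by diethylamino in place of dimethylamino on a saturated chain carbon bound to a double-bonded chain carbon, the same change as from compound 1 to compound 2, made on the other core. Among the measured compounds shown here, only one earlier instance of this change is known, so the expectation rests on that single pair. In this assay compound 4 is expected to give 16000 nM, with a likely range from 6000 nM to 45000 nM. For the measured compounds named here, the expected step is a 3.8-fold higher number from compound 3 to compound 4 (0.58 log units; beyond the scatter), about the size of the earlier one, because a 4.7-fold higher number from compound 1 to compound 2 (0.67 log units; beyond the scatter) is the only guide available.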

Compound 4, half-maximal inhibitory concentration: 4270 nM
For compound 4 the middle estimate is 3.7-fold (0.57 log units) above the measured one; the measured number lies below the stated range.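

On the core of compound 3, diethylamino in place of dimethylamino gave a 1.0-fold higher number from compound 3 to compound 4 (0.01 log units; within the scatter), so in this assay the change did not carry over from the core of compound 1 with its earlier size: the same change on two cores in this assay, a 4.7-fold higher number (0.67 log units; beyond the scatter) from compound 1 to compound 2 and a 1.0-fold higher number (0.01 log units; within the scatter) from compound 3 to compound 4, 4.6-fold (0.66 log units) apart, beyond the scatter of two such steps. Read the other way, the ring change on the diethylamino compounds gave a 1.4-fold lower number from compound 2 to compound 4 (0.13 log units; within the scatter), which does not match its step on the dimethylamino compounds: the same change on two cores in this assay, a 3.4-fold higher number (0.53 log units; beyond the scatter) from compound 1 to compound 3 and a 1.4-fold lower number (0.13 log units; within the scatter) from compound 2 to compound 4, 4.6-fold (0.66 log units) apart, beyond the scatter of two such steps. The two changes therefore do not simply add up across these four compounds, but this single pair of pairs does not show why, nor how the change behaves on any further core.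

Still open, as far as these compounds go, is how the two cores respond to other amines on this chain, such as dipropylamino or a cyclic amine like morpholine.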